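This account rests on a few compounds, and the source may have more. Where it says the series, first, only, none or still open, it means among the compounds named here.

Compound 1, `Cc1nn(C)c2c1C(c1ccccc1)=NCC(=O)N2`: 16 mg/kg
Compound 2, `CCc1nn(C)c2c1C(c1ccccc1)=NCC(=O)N2`: 8 mg/kg

Both were tested in a functional assay on the whole organism with Rattus norvegicus as the target; on this read-out higher numbers stand for an effect only at larger amounts of compound and lower numbers for an effect already at smaller amounts. Compound 1 has the higher of the two numbers; its nearest neighbour is compound 2, and a 2.0-fold lower number from compound 1 to compound 2 (0.30 log units; within the scatter). The unmeasured compound 3, `Cc1nn(C)c2c1C(c1cccc(Cl)c1)=NCC(=O)N2`, differs from compound 1 in one place:
chloro in place of hydrogen on an aromatic carbon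
Within the data shown here, no measured step touches this part of the shared core; the only known step, a 2.0-fold lower number from compound 1 to compound 2 (0.30 log units; within the scatter), concerns another place. With nothing to build on, no shift beyond the scatter is expected in this assay. The estimated change is a 1.3-fold lower number from compound 1 to compound 3 (0.12 log units; within the scatter). Compound 3 is therefore expected to give 12 mg/kg, within a range from 4 mg/kg to 40 mg/kg.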

Compound 3, minimum effective dose: > 500 mg/kg
Compound 3: only a limit was reported; the forecaster's own chance of this, stated with the estimate: 5%; at least 41-fold (1.61 log units) between middle value and limit.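

The earlier compounds shown here changed only another place, so they said nothing about this ring. Here one chlorine atom on an aromatic carbon, meta to a large group, brings an at least 31-fold higher number from compound 1 to compound 3 (1.49 log units; beyond the scatter), which shows that a single heavy atom at this place can shift the dose needed far beyond the scatter. The number for compound 3 is a limit, not a measured value: the limit of > 500 mg/kg in this assay, at which 1 of the 3 values shown sits.

Whether this holds for chloro alone or for any group at this place stays open, as fluoro, methyl and methoxy are not among the compounds shown. How chloro behaves on the other carbons of this ring is open too.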